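Fluorophenyl series on the shared core: ortho versus para

The compounds below may be only part of what the source reports. "The series", "measured", "known", "first", "only" and "open" are said of these compounds alone.

Measured so far in a functional assay on NCI-H460 cells (Homo sapiens) for antiproliferative activity, with a stated time of 72 h; a higher number here means a weaker inhibitor, a lower number a stronger inhibitor:
- Compound 1, `Nc1ncnn2c([C@@H]3O[C@H](CO)[C@@H](O)[C@H]3O)cc(C#CC3CC3)c12`: 80 nM
- Compound 2, `Nc1ncnn2c([C@@H]3O[C@H](CO)[C@@H](O)[C@H]3O)cc(-c3ccccc3)c12`: a limit of the assay only, > 100000 nM
- Compound 3, `Nc1ncnn2c([C@@H]3O[C@H](CO)[C@@H](O)[C@H]3O)cc(-c3ccc(F)cc3)c12`: 55500 nM

Compound 3 gives the highest number among the measured compounds; the nearest value is that of compound 1, with a 690-fold higher number from compound 1 to compound 3 (2.84 log units; beyond the scatter). The other aryl analogue, compound 2, shows an at least 1200-fold higher number from compound 1 to compound 2 (3.09 log units; beyond the scatter), and of the two aryl compounds the step of an at least 1.8-fold lower number from compound 2 to compound 3 (0.25 log units; that floor lies within the scatter) rests on a limit (the limit of > 100000 nM in this assay, at which 1 of the 3 values shown sits) and changes little.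

Compound 4, `Nc1ncnn2c([C@@H]3O[C@H](CO)[C@@H](O)[C@H]3O)cc(-c3ccccc3F)c12`, differs from compound 3 by 2-fluorophenyl in place of 4-fluorophenyl on an aromatic carbon. Going by the values given here, no measured step covers moving the fluorine within the phenyl group; the only step that bears on it is the fluoro-for-hydrogen change from compound 2 to compound 3, which stays inside the scatter. Both aryl compounds sit far above compound 1, so compound 4 is expected to remain in that same weak region, and the step of a 1.1-fold higher number from compound 3 to compound 4 (0.03 log units; within the scatter) is estimated to lie within the scatter, with no direction claimed. Compound 4 is therefore expected to give about 60000 nM in this assay, somewhere between 15000 nM and 150000 nM, with a real chance that only a limit is returned.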

Compound 4, half-maximal inhibitory concentration: > 100000 nM
Compound 4: only a limit was reported; the forecaster's own chance of this, stated with the estimate: 35%; at least 1.6-fold (0.22 log units) between middle value and limit.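

In this assay compound 4 returns only a limit, > 100000 nM, so 2-fluorophenyl at this position gives no readable potency. The step of an at least 1.8-fold higher number from compound 3 to compound 4 (0.25 log units; that floor lies within the scatter) is only a floor, so moving the fluorine within the phenyl group is not shown to change the result beyond the scatter, while an at least 1200-fold higher number from compound 1 to compound 4 (3.09 log units; beyond the scatter) extends the large loss seen with the other two aryl groups to a third aryl group at this position. The step from compound 2 to compound 4 cannot be read, so the effect of adding a fluorine in the 2-fluorophenyl arrangement stays unknown because both values are limits: the limit of > 100000 nM in this assay, at which 2 of the 4 values shown sit.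

The compounds shown leave open whether any aryl group at this position can approach compound 1, as all three sit far from it and two of them give no number. They also leave open which part of 2-cyclopropylethynyl carries its advantage over the aryl groups, a question that a plain ethynyl, a longer alkyl chain on the alkyne, or an amine on the phenyl ring would bear on.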